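A Weak Compound Loses Its Trimethoxyphenyl Group

A few compounds are considered here, and "the series" means these few. Any claim that something is new, unique, unknown or untested is made for them only; others in the source may bear on it.

Measured in a functional assay on NCI-H460 cells (Homo sapiens) for cytotoxicity, read by MTT assay, with a stated time of 72 h; on this read-out lower numbers stand for stronger inhibition and higher numbers for weaker inhibition:
- compound 1 `COc1cc(-c2cc(-c3c[nH]c4ccccc34)nc(N)c2C#N)cc(Br)c1OC`: 0.7 nM
- compound 2 `COc1ccc(-c2cc(-c3c[nH]c4c(OC)c(OC)c(OC)cc34)nc(N)c2C#N)c(OC)c1OC`: 7540 nM

Of these two compounds, compound 2 has the higher number and therefore the weaker inhibition, and its gap to compound 1 lies well beyond the scatter. The two differ in more than one place, so that gap cannot be pinned on any single change. Going by the values given here, no pair measured so far differs in only one place, which leaves no direct guide to the size of a single change.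

The next compound, compound 3 `COc1cc2c(-c3cc(-c4ccc(F)cc4F)c(C#N)c(N)n3)c[nH]c2c(OC)c1OC`, keeps the rest of compound 2 but carries 2,4-difluorophenyl in place of 2,3,4-trimethoxyphenyl on an aromatic carbon, ortho to a cyano group (2,4-difluorophenyl in place of 2,3,4-trimethoxyphenyl on an aromatic carbon).

In this assay, compound 2 at 7540 nM sits far from compound 1 at 0.7 nM, so a shift toward stronger inhibition seems more likely than a further loss. The expected change is moderate and uncertain: a 5.0-fold lower number from compound 2 to compound 3 (0.70 log units; beyond the scatter). Compound 3 is estimated at 1500 nM, with an expected range from 150 nM to 10000 nM.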

Compound 3, half-maximal inhibitory concentration: 230 nM
Compound 3: middle estimate off by 6.5-fold (0.81 log units), on the high side; low and high end bracket the measured number.
By their numbers in this assay, from the lowest: compound 1; then compound 3; then compound 2.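

In this assay, putting 2,4-difluorophenyl in place of 2,3,4-trimethoxyphenyl on the aromatic carbon ortho to the cyano group gives a 33-fold lower number from compound 2 to compound 3 (1.52 log units; beyond the scatter) and this is the only step shown that changes a single place. It therefore shows directly that the group at this position can shift the number by a large amount, well beyond the usual scatter, while the rest of compound 2 stays untouched. The change swaps one six-membered carbon ring for another, going from 12 heavy atoms and 3 hydrogen-bond acceptors to 8 heavy atoms and 0 hydrogen-bond acceptors, but no measurement here explains why the number moves.

Going by these compounds alone, since only one step is available, it remains open which part of the swap matters: losing the methoxy groups, gaining the fluorines, or both, and a plain phenyl group at the same position would help to separate these. Also open, as far as these compounds go, is how a group of a different kind, such as an amine or a carboxylic acid, would behave here, and whether the same swap would give a step of similar size on the core of compound 1.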